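Removing the fluorophenyl group from compound 3

The source may hold more compounds than are shown below. What is called first, only, known or untested is meant among the compounds shown, and "the series" means these compounds.

Values from an ADME assay on microsomes from liver (Mus musculus) for metabolic stability, with a stated time of 10 min, tested at 0.5 uM; a higher number here means that more of the compound is left, a lower number that less of the compound is left
- Compound 1 (`Cc1noc(C)c1[C@@H]1C[C@@](C)(c2ccc(F)cc2F)N=C(N)S1`) gives 72%
- Compound 2 (`Cc1onc(-c2ccccc2)c1[C@@H]1C[C@@](C)(c2ccc(F)cc2F)N=C(N)S1`) gives 12%
- Compound 3 (`Cc1noc(-c2ccc(F)cc2)c1[C@@H]1C[C@@](C)(c2ccc(F)cc2F)N=C(N)S1`) gives 53%

Compound 3 stands in the middle of these three, with compound 1 higher and compound 2 lower, both gaps beyond the scatter. Compound 4 (`Cc1nocc1[C@@H]1C[C@@](C)(c2ccc(F)cc2F)N=C(N)S1`) has not yet been measured. It keeps the shared core, and the change from compound 3 is hydrogen in place of 4-fluorophenyl on an aromatic carbon and in short it puts hydrogen in place of 4-fluorophenyl on an aromatic carbon, next to the ring oxygen.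

For the measured compounds named here, two measured steps bear on this. The closer one is a number 19 percentage points lower from compound 1 to compound 3 (beyond the scatter) and it concerns the same ring carbon, where methyl gives way to 4-fluorophenyl. The other is a number 60 percentage points lower from compound 1 to compound 2 (beyond the scatter) and it places a phenyl on a different ring carbon, so it counts for less here. Read backwards, the closer step suggests that losing the 4-fluorophenyl group should raise the number. Going by the values given here, no measured compound carries hydrogen at this carbon, so hydrogen may not match methyl. The expected change is a number 15 percentage points higher from compound 3 to compound 4 (beyond the scatter) and that would be a modest rise. For compound 4 the estimated value is 68% with an expected range from 52% to 84% in this assay's terms.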

Compound 4, percent of the compound remaining: 80%
Compound 4: middle estimate off by 12 percentage points, on the low side, within the range that was stated.
By their numbers in this assay, from the lowest: compound 2; then compound 3; then compounds 1 and 4 (each within the scatter of the next).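

In this assay, taking the 4-fluorophenyl group off this carbon, next to the ring oxygen, gives a number 27 percentage points higher from compound 3 to compound 4 (beyond the scatter) and is a clear gain in the percentage of compound left. This is a larger step than the earlier comparison of methyl with 4-fluorophenyl at the same carbon, and it shows that the ring carbon can carry no substituent at all without any loss in this read-out. Hydrogen and methyl cannot be told apart here, as the comparison gives a number 8 percentage points higher from compound 1 to compound 4 (within the scatter) and so the lower number of compound 3 goes with the 4-fluorophenyl group alone, while nothing measured in this set explains why the numbers fall as they do.

The compounds shown leave open how an intermediate group at this carbon, such as an ethyl chain, a methoxy group or a small amine, would read, and so whether the number falls gradually or only once a whole aromatic ring is attached. They also leave open whether an unsubstituted phenyl at this carbon would read like the 4-fluorophenyl group, which would show what the fluorine contributes.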